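Trimethoxyphenyl pyrazole chalcone analogues in myeloma cell growth

The compounds below may be only part of what the source reports. "The series", "measured", "known", "first", "only" and "open" are said of these compounds alone.

Compound 1 `COc1cc(-c2cc(/C=C/C(=O)c3ccc(N)cc3)[nH]n2)cc(OC)c1OC` carries a 4-aminophenyl on the carbonyl carbon. Among the measured compounds shown here, in a functional assay on RPMI-8226 cells (Homo sapiens) for inhibition, read by sulforhodamine B assay, with a stated time of 48 h (a lower number here means a stronger inhibitor of growth, a higher number a weaker inhibitor of growth), compound 1 gives 470 nM, the second highest of the three numbers so far. Its nearest neighbour is compound 3 `COc1ccc(-c2cc(/C=C/C(=O)c3ccc(N)cc3)[nH]n2)cc1`, which in this assay gives 600 nM, a difference within the scatter. Furthest is compound 2 `COc1ccc(-c2cc(/C=C/C(=O)c3ccc(OC)c(OC)c3)[nH]n2)cc1`, which in this assay gives 320 nM, also within the scatter of compound 1. Compounds 2 and 3 share the rest of their structure and differ only at the carbonyl aryl, and their two numbers lie within the scatter of each other.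

Compound 4 `COc1ccc(C(=O)/C=C/c2cc(-c3cc(OC)c(OC)c(OC)c3)n[nH]2)cc1OC` has not yet been measured. It differs from compound 1 as follows: 3,4-dimethoxyphenyl in place of 4-aminophenyl on a carbonyl carbon. The same exchange, seen through the pair of compound 2 and compound 3, did not move the number beyond the scatter. For compound 4 in this assay a modestly lower number than compound 1 is therefore expected, not beyond the scatter. The expected step from compound 1 to compound 4 is a 1.4-fold lower number from compound 1 to compound 4 (0.15 log units; within the scatter). Compound 4 is estimated at 330 nM, with a range from 130 nM to 850 nM.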

Compound 4, concentration for 50% growth inhibition: 240 nM
For compound 4 the middle estimate is 1.4-fold (0.14 log units) above the measured one; low and high end bracket the measured number.
By their numbers in this assay, from the lowest: compounds 4, 2, 1 and 3 (each within the scatter of the next, the first and the last beyond it).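

In this assay, the exchange of 4-aminophenyl for 3,4-dimethoxyphenyl on the carbonyl carbon now has a second reading on the core of compound 1, a 2.0-fold lower number from compound 1 to compound 4 (0.29 log units; within the scatter), which adds to the within-scatter pair of compound 3 at 600 nM and compound 2 at 320 nM. On both cores, therefore, the hydrogen-bond donor of 4-aminophenyl can be lost, and 3,4-dimethoxyphenyl can take its place, without the number leaving the scatter. No measurement bears on why this position accepts the exchange.

On these data alone, the four compounds carry only these two groups at this position, so it remains open whether any replacement moves the number beyond the scatter. A carboxylic acid or a morpholine on the phenyl ring, or an unsubstituted phenyl, would test this.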